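Replacing a Pyridylmethyl Arm with a Furan Ring

The source may report more compounds than this note shows. Statements on the series, on what has been measured and on what is new or still open speak of the compounds shown alone.

Compound 1, `CCOC(=O)c1ccc(-c2nn(Cc3cccc(F)c3)c3ccccc23)cc1`, in a functional assay on cells (Platelet, Homo sapiens) for inhibition (a lower number here means a stronger inhibitor, a higher number a weaker inhibitor), gives > 10000 nM, which is a limit of the assay rather than a number.
Compound 2, `CCOC(=O)c1ccc(-c2nn(Cc3ccncc3)c3ccccc23)cc1`, in this assay gives > 10000 nM, again only a limit.

Compound 2 therefore stands at the edge of what this assay reports, and compound 1 stands at the same edge. Going by the values given here, the one measured step, a step that the two limits leave unreadable from compound 1 to compound 2, cannot be read in size or direction because the limit of > 10000 nM in this assay, at which 2 of the 2 values shown sit, is where both values sit.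

Compound 3, `CCOC(=O)c1ccc(-c2nn(-c3ccco3)c3ccccc23)cc1`, differs from compound 2 in a single place: furan-2-yl in place of (pyridin-4-yl)methyl on an aromatic nitrogen. Among the compounds with values here, no measured step bears on this change, and the only step available gives no size. With nothing pointing towards a gain, compound 3 is expected to remain at the limit, so the estimated step that the limit leaves unreadable from compound 2 to compound 3 is expected to be none beyond the scatter. The estimate for compound 3 is 15000 nM, with a range from 5000 nM to 50000 nM.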

Compound 3, half-maximal inhibitory concentration: > 10000 nM
Compound 3 was reported as a limit; the forecaster's own chance of this, stated with the estimate: 80%; the middle value is on the limit's open side.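

Going by these compounds alone, no step among compound 1, compound 2 and compound 3 can be read, in size or in direction, because all three values are the same limit and not numbers: the limit of > 10000 nM in this assay, at which 3 of the 3 values shown sit. From the compounds shown here alone, whether any group on the aromatic nitrogen of the shared core can give a readable value in this assay stays open.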